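A few compounds are considered here, and "the series" means these few. Any claim that something is new, unique, unknown or untested is made for them only; others in the source may bear on it.

Compound 1 `O=C(/C=C/c1ccc2c(c1)B(O)OC2)c1ccccc1` gives 6100 nM in a functional assay on HCT-116 cells (Homo sapiens) for cytotoxicity, read by MTT assay, with a stated time of 48 h; a higher number here means a weaker inhibitor, a lower number a stronger inhibitor; compound 2 `O=C(/C=C/c1ccc2c(c1)B(O)OC2)c1ccc(-c2ccccc2)cc1` gives 9500 nM; compound 3 `O=C(/C=C/c1ccc2c(c1)B(O)OC2)c1cccnc1` gives 20500 nM.

Compound 3 stands highest of the three numbers in this assay, with compound 2 nearest and compound 1 furthest. Compound 4 `O=C(/C=C/c1ccc2c(c1)B(O)OC2)c1ccc(Br)cc1` differs from it by 4-bromophenyl in place of pyridin-3-yl on a carbonyl carbon. For the measured compounds named here, two measured steps bear on this. The step of a 3.4-fold higher number from compound 1 to compound 3 (0.53 log units; beyond the scatter) is the reverse of the present ring exchange, so a return toward the number of compound 1 is expected. The step of a 1.6-fold higher number from compound 1 to compound 2 (0.19 log units; within the scatter) shows that a further group on an aromatic carbon of that ring shifted the number little. Compound 4 is therefore expected to show a lower number, a step of a 3.2-fold lower number from compound 3 to compound 4 (0.50 log units; beyond the scatter). Compound 4 is estimated at 6500 nM, within 2800 nM to 15000 nM.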

Compound 4, half-maximal inhibitory concentration: 9900 nM
Compound 4: middle estimate off by 1.5-fold (0.18 log units), on the low side; measured number inside the range.
By their numbers in this assay, from the lowest: compounds 1, 2 and 4 (each within the scatter of the next); then compound 3.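

In this assay, 4-bromophenyl in place of pyridin-3-yl on the carbonyl carbon gives a 2.1-fold lower number from compound 3 to compound 4 (0.32 log units; beyond the scatter), so a carbon-only ring carrying a further group also stands apart from the nitrogen-containing ring. An added bromo group stays within the scatter, with a 1.6-fold higher number from compound 1 to compound 4 (0.21 log units; within the scatter), and so does bromo in place of phenyl, with a 1.0-fold higher number from compound 2 to compound 4 (0.02 log units; within the scatter). Nothing available explains these steps.

From the compounds shown here alone, whether an amine or a carboxylic acid on that ring would also stay within the scatter remains open.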